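This account rests on a few compounds, and the source may have more. Where it says the series, first, only, none or still open, it means among the compounds named here.

Measured so far:
compound 1, `O=C(CCc1ccccc1)Nc1nc2ccccc2c(=O)s1`, 42.7 nM
compound 2, `O=C(COc1cccc(Cl)c1)Nc1nc2ccccc2c(=O)s1`, 661 nM

Of the compounds shown here, two have been measured in an assay on mitochondria (strain Sprague-Dawley) for inhibition of Amine oxidase [flavin-containing] B (Rattus norvegicus), read by fluorescence and Amplex Red, with stated times of 30 min and 45 min; a lower number here means a stronger inhibitor, a higher number a weaker inhibitor. Compound 1 gives 42.7 nM, the lowest of the two numbers. Its nearest neighbour is compound 2, which gives 661 nM; the gap between the two lies beyond the usual scatter. The two structures differ in more than one place, so only their values can be compared, not a single change.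

The step considered here leads from compound 1 to compound 3, `O=C(CCc1ccccc1Br)Nc1nc2ccccc2c(=O)s1`, which has not yet been measured in this assay. The change is bromo in place of hydrogen on an aromatic carbon. Within the data shown here, no step between measured compounds isolates this kind of change, so the expectation rests on compound 1 alone and on the size of its value. A bromo group entering here is expected to move the number only modestly, if at all: the step of a 1.4-fold higher number from compound 1 to compound 3 (0.15 log units; within the scatter) is estimated to stay within or near the scatter. Compound 3 is therefore expected to give about 60 nM, within a range of 20 nM to 200 nM.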

Compound 3, half-maximal inhibitory concentration: 64 nM
Compound 3: middle estimate off by 1.1-fold (0.03 log units), on the low side; measured number inside the range.
By their numbers in this assay, from the lowest: compounds 1 and 3 (each within the scatter of the next); then compound 2.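

In this assay the change from phenyl to 2-bromophenyl gives a 1.5-fold higher number from compound 1 to compound 3 (0.18 log units; within the scatter) and thus shows, for the first time among these compounds, what a single change at this position does. A bromo group on this aromatic carbon, ortho to a large group, is accepted here without a change that could be told from the scatter, so compound 1 and compound 3 cannot be separated by this measurement. Nothing at hand explains why the number holds at this position.

This single step does not show whether the same position would accept other groups, such as fluoro, methoxy, an amine or a carboxylic acid. Nor does it show how a bromo group would behave at the other carbons of this ring.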